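The source may hold more compounds than are shown below. What is called first, only, known or untested is meant among the compounds shown, and "the series" means these compounds.

Working notes on the series. Compound 1 `O=C1O[C@@H](CN2CCCCC2)CN1c1ccc(-n2cc(-c3ccccn3)cn2)c(F)c1` is the reference point. In an ADME assay on HEK293-A cells (Homo sapiens) for cytotoxicity, read by MTT assay, with a stated time of 48 h (on this read-out lower numbers stand for stronger inhibition and higher numbers for weaker inhibition), compound 1 gives > 400 ug/mL, which is a limit of the assay and not a number. Compound 2 `CC(=O)OC[C@H]1CN(c2ccc(-n3cc(-c4ccccn4)cn3)c(F)c2)C(=O)O1` likewise gives > 400 ug/mL in this assay, again a limit. Compound 3 `COC(=O)NC[C@H]1CN(c2ccc(-n3cc(-c4ccccn4)cn3)c(F)c2)C(=O)O1` gives 306 ug/mL in this assay. Compound 1 therefore stands only at a limit, and so does one of the two comparators; see (the limit of > 400 ug/mL in this assay, at which 2 of the 3 values shown sit). The measured steps read a step that the two limits leave unreadable from compound 1 to compound 2, an at least 1.3-fold lower number from compound 1 to compound 3 (0.11 log units; that floor lies within the scatter) and an at least 1.3-fold lower number from compound 2 to compound 3 (0.11 log units; that floor lies within the scatter).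

The step to compound 4 `CCNC(=O)NC[C@H]1CN(c2ccc(-n3cc(-c4ccccn4)cn3)c(F)c2)C(=O)O1` is (ethylcarbamoyl)amino in place of piperidin-1-yl on a saturated chain carbon bound to a saturated ring carbon. Of the measured steps, the two that replace the piperidin-1-yl group bear on it, and neither reaches beyond the scatter. The expectation in this assay is therefore a step of an at least 1.1-fold lower number from compound 1 to compound 4 (0.05 log units; that floor lies within the scatter), that is no change beyond the scatter, and compound 4 is estimated at 350 ug/mL, with a range from 200 ug/mL to 450 ug/mL, because compound 3 gives 306 ug/mL after the related change.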

Compound 4, half-maximal inhibitory concentration: 29 ug/mL
The estimate for compound 4 lay 12-fold (1.08 log units) above the measured number, and the stated range ends above it.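

In this assay, within the data shown here, the place on a saturated chain carbon bound to a saturated ring carbon now shows a large response, which the earlier compounds did not reveal: (ethylcarbamoyl)amino in place of piperidin-1-yl gives an at least 13-fold lower number from compound 1 to compound 4 (1.13 log units; beyond the scatter), and in place of acetoxy it gives an at least 13-fold lower number from compound 2 to compound 4 (1.13 log units; beyond the scatter). The step free of any limit is ethylamino in place of methoxy on a carbonyl carbon, which gives an 11-fold lower number from compound 3 to compound 4 (1.02 log units; beyond the scatter), so the large response turns on the group at that carbonyl carbon and not merely on a carbonyl-bearing amino group at the chain carbon. The two steps that start from compound 1 and compound 2 are floors only: the limit of > 400 ug/mL in this assay, at which 2 of the 4 values shown sit.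

The compounds shown do not separate the ethyl chain of the ethylamino group from its nitrogen. A methylamino or propylamino group on the same carbonyl carbon would tell these apart.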